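This account rests on a few compounds, and the source may have more. Where it says the series, first, only, none or still open, it means among the compounds named here.

Measured in an ADME assay on Huh-7 cells (Homo sapiens) for cytotoxicity, read by WST assay; on this read-out lower numbers stand for higher toxicity in this test and higher numbers for lower toxicity in this test:
- Compound 1 `C[C@H]1CC[C@H](c2ccccc2-c2cc(-c3ccccc3)sc2C(=O)O)CC1`: 20000 nM
- Compound 2 `Cc1ccc(-n2nncc2-c2cc(-c3ccccc3)sc2C(=O)O)cc1`: > 30000 nM

For compound 2 the reading > 30000 nM is a limit of the assay, not a number. Compound 3 `C[C@H]1CC[C@H](n2nncc2-c2cc(-c3ccccc3)sc2C(=O)O)CC1` has not been measured. It differs from compound 2 in one place, with 4-methylcyclohexyl in place of 4-methylphenyl on an aromatic nitrogen. Within the data shown here, no measured pair shows this change on its own, so any step in this assay can only be expected. Compound 1, which carries 4-methylcyclohexyl in a different setting, gives 20000 nM, and this points to a small expected move towards lower numbers, or none beyond the scatter. The expected change is an at least 1.0-fold lower number from compound 2 to compound 3 (0.02 log units; that floor lies within the scatter). For compound 3 the estimated value is 28000 nM, with an expected range of 15000 nM to 38000 nM.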

Compound 3, half-maximal cytotoxic concentration: > 50000 nM
Compound 3: only a limit was reported (the forecaster's own chance of this, stated with the estimate: 55%); middle value at least 1.7-fold (0.25 log units) away from the limit.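

Among these compounds, compound 2 and compound 3 both gave limits rather than numbers, and no step between them can be read. The compounds shown leave open how far, and in which direction, 4-methylcyclohexyl in place of 4-methylphenyl on an aromatic nitrogen moves this read-out.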